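Thiourea series: ring swap on the thiocarbonyl carbon

A few compounds are considered here, and "the series" means these few. Any claim that something is new, unique, unknown or untested is made for them only; others in the source may bear on it.

Measured so far:
Compound 1 `Cc1ccnc(/C(N)=N/NC(=S)N2CCSCC2)c1`, in a functional assay on HeLa cells (Homo sapiens) for cytotoxicity, read by MTT assay, with a stated time of 72 h (a higher number here means a weaker inhibitor, a lower number a stronger inhibitor), compound 1 gives 15500 nM.
Compound 2 `N/C(=N\NC(=S)N1CCSCC1)c1ccccn1`, compound 2 gives 7800 nM.
Compound 3 `N/C(=N\NC(=S)N1CCN(c2ccccn2)CC1)c1ccccn1`, compound 3 gives 8600 nM.

Compound 1 carries the highest number of the three, but its gaps to compound 3 and to compound 2 both fall inside the usual scatter, so no order among the three can be read from these values. Among the measured compounds shown here, the one single-point step on record, a 2.0-fold lower number from compound 1 to compound 2 (0.30 log units; within the scatter), is itself within the scatter.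

Compound 4 `Cc1ccnc(/C(N)=N/NC(=S)N2CCCC2)c1` differs from compound 1 in one place: pyrrolidin-1-yl in place of thiomorpholin-4-yl on a thiocarbonyl carbon. For the measured compounds named here, no measured pair changes the ring on the thiocarbonyl carbon alone; compound 2 and compound 3 carry different rings there, and their values lie close together, which is all that can be said of that position. The recorded step from compound 1 to compound 2 concerns the methyl on the aromatic carbon, not this ring, so it does not bear on the change. With nothing to anchor a direction, compound 4 is expected to sit near compound 1, a step of a 1.1-fold lower number from compound 1 to compound 4 (0.04 log units; within the scatter), not beyond the scatter. The estimate for compound 4 is 14000 nM, with a range from 5000 nM to 40000 nM.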

Compound 4, half-maximal inhibitory concentration: 1900 nM
Estimate against measurement, compound 4: 7.4-fold (0.87 log units) above; measured number outside the range, below it.
By their numbers in this assay, from the lowest: compound 4; then compounds 2, 3 and 1 (each within the scatter of the next).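

Among the compounds shown here, the ring on the thiocarbonyl carbon now gives the first single-place step in this assay that lies beyond the scatter: with pyrrolidin-1-yl in place of thiomorpholin-4-yl, the record shows an 8.2-fold lower number from compound 1 to compound 4 (0.91 log units; beyond the scatter) on the same methyl-bearing core. For the compounds shown here, the earlier compounds could not show this, since compound 2 and compound 3 differ in their rings at this position but have values within the scatter of each other, and the only earlier step concerned the methyl on the aromatic carbon. No measurement on record explains the new step.

As far as these compounds go, whether the step carries over to the core of compound 2, which lacks the methyl, remains open. Also open, from the compounds shown here alone, is how piperidin-1-yl, morpholin-4-yl or an open-chain diethylamino group on the thiocarbonyl carbon would read.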